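Two esters at the assay limit and a valine analogue

The source may report more compounds than this note shows. Statements on the series, on what has been measured and on what is new or still open speak of the compounds shown alone.

compound 1 `CCCCCCCCCCC[C@@H](C[C@@H]1OC(=O)[C@H]1CCCCCC)OC(=O)[C@H](CC(C)C)NC(=O)OC(C)(C)C` > 25000 nM
compound 2 `CCCCCCCCCCC[C@@H](C[C@@H]1OC(=O)[C@H]1CCCCCC)OC(=O)CNC(=O)OCc1ccccc1` > 25000 nM

In an assay on COS-7 cells for inhibition of diacylglycerol lipase-alpha (Homo sapiens), read by scintillation counting (on this read-out lower numbers stand for stronger inhibition and higher numbers for weaker inhibition), compound 1 gives > 25000 nM, which is a limit of the assay and not a number. Compound 2 gives > 25000 nM in this assay, again a limit rather than a measured value. Everything measured so far sits at the limit of > 25000 nM in this assay, at which 2 of the 2 values shown sit, so no step between the two compounds can be sized, and compound 2 stands simply at that limit, without a number of its own to compare.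

Compound 3 `CCCCCCCCCCC[C@@H](C[C@@H]1OC(=O)[C@H]1CCCCCC)OC(=O)[C@@H](NC(C)=O)C(C)C` has not yet been measured in this assay. It differs from compound 2 in one place: 1-acetamido-2-methylpropyl in place of ((benzyloxycarbonyl)amino)methyl on a carbonyl carbon. Among the compounds with values here, with no measured step available, the expectation rests only on the two limits, and a change of this kind among compounds that both sit at the limit gives no ground to expect a move into the measurable range. Compound 3 is expected to give 30000 nM in this assay, in a range from 8000 nM to 100000 nM, most likely reported again as a limit. The step that the limit leaves unreadable from compound 2 to compound 3 is expected to be none beyond the usual scatter.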

Compound 3, half-maximal inhibitory concentration: 460 nM
Compound 3: middle estimate off by 65-fold (1.81 log units), on the high side, outside the stated range (below it).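

In this assay, within the data shown here, putting 1-acetamido-2-methylpropyl in place of ((benzyloxycarbonyl)amino)methyl on a carbonyl carbon brings an at least 54-fold lower number from compound 2 to compound 3 (1.73 log units; beyond the scatter), which shows that the read-out at this place responds to the group carried, something the earlier compounds could not show. Compound 2 gives > 25000 nM, which is a limit and not a number. Compound 3 gives 460 nM, a measured number, so the step is bounded on one side only and its full size cannot be read: the limit of > 25000 nM in this assay, at which 2 of the 3 values shown sit.

The one change takes away the six-membered aromatic ring, lowers the heavy-atom count and adds a defined stereocentre all together, and the compounds shown cannot tell which of these parts carries the step. As far as these compounds go, it also remains open whether a free amine in place of the acetamido part, or a longer chain in place of the 2-methylpropyl part, would keep the number in the measurable range or return it to the limit.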